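Amide Aryl Change on the Weakest of Three Compounds

A few compounds are considered here, and "the series" means these few. Any claim that something is new, unique, unknown or untested is made for them only; others in the source may bear on it.

Among the three compounds measured in a functional assay on SK-BR-3 cells (Homo sapiens) for antiproliferative activity, read by MTT assay, with a stated time of 72 h (a higher number here means a weaker inhibitor, a lower number a stronger inhibitor), compound 2 `CCN1CCN(c2cc(C)c3cc(NC(=O)c4ccccc4C)ccc3n2)CC1` gives 29200 nM and stands highest: its nearest neighbour, compound 1 `Cc1cc(NCCN(C)C)nc2ccc(NC(=O)c3ccc(Cl)c(Cl)c3)cc12`, gives 6670 nM, and compound 3 `Cc1cc(NCCN2CCCCC2)nc2ccc(NC(=O)c3ccc(Cl)c(Cl)c3)cc12` gives 1800 nM. Within the data shown here, the one single-point step measured so far, a 3.7-fold lower number from compound 1 to compound 3 (0.57 log units; beyond the scatter), concerns the amine end of the side chain and not the amide. Compound 4 `CCc1ccc(C(=O)Nc2ccc3nc(N4CCN(CC)CC4)cc(C)c3c2)cc1` differs from compound 2 only at the amide: 4-ethylphenyl in place of 2-methylphenyl on a carbonyl carbon. Among the measured compounds shown here, no measured pair tests this kind of change; compounds 1 and 3 carry a different aryl amide altogether and differ from compound 2 in several places, so their lower numbers cannot be assigned to the amide alone. With nothing directly comparable, the expectation for the step from compound 2 to compound 4 is no change beyond the scatter, and the step is estimated at a 1.3-fold lower number from compound 2 to compound 4 (0.12 log units; within the scatter). Compound 4 is therefore expected to give about 22000 nM in this assay, within a range of 6000 nM to 70000 nM.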

Compound 4, half-maximal inhibitory concentration: 9850 nM
For compound 4 the middle estimate is 2.2-fold (0.35 log units) above the measured one; measured number inside the range.
By their numbers in this assay, from the lowest: compound 3; then compounds 1 and 4 (each within the scatter of the next); then compound 2.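

At the amide of compound 2, the aryl group on the carbonyl carbon proves able to shift the number in this assay: 4-ethylphenyl in place of 2-methylphenyl gives a 3.0-fold lower number from compound 2 to compound 4 (0.47 log units; beyond the scatter). Among these compounds, the earlier compounds could not show this, since the only single-point step among them lies at the amine end of the side chain. Among the compounds shown here, this pair is the first in which the amide aryl changes while the rest of the molecule stays the same.

The compounds shown leave open whether the step follows from losing the 2-methyl group or from gaining the 4-ethyl group, which plain phenyl or 4-methylphenyl on the same carbonyl would help to separate, and whether it would carry over to the side-chain amines of compound 1 and compound 3. No measured information bears on what lies behind the step.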